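The source may hold more compounds than are shown below. What is called first, only, known or untested is meant among the compounds shown, and "the series" means these compounds.

Among the compounds with values here, compound 1, the isatin-type ester with the structure `COC(=O)/C=C/c1ccc2c(c1)C(=O)C(=O)N2Cc1cc(C)cc(C)c1`, is one of three compounds measured in a functional assay on K562 cells (Homo sapiens) for cytotoxicity, read by MTT assay, with a stated time of 48 h; a lower number here means a stronger inhibitor, a higher number a weaker inhibitor. In this assay compound 1 gives 40 nM. Compound 3, with the structure `CCCCOC(=O)/C=C/c1ccc2c(c1)C(=O)C(=O)N2Cc1ccc(OC)cc1`, gives 40 nM, the same number at the digits reported, so the two sit together at the lowest end of the set. Compound 2, with the structure `COC(=O)/C=C/c1cccc2c1C(=O)C(=O)N2Cc1ccc(OC)cc1`, gives 350 nM, a number clearly higher than that of compound 1 and beyond the usual scatter.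

Compound 4, with the structure `COC(=O)/C=C/c1ccc2c(c1)C(=O)C(=O)N2C`, has not yet been measured. It differs from compound 1 in a single place: hydrogen in place of 3,5-dimethylphenyl on a saturated chain carbon bound to an amide-type nitrogen in a ring. Within the data shown here, none of the measured pairs differs in one place only, so there is no measured step to lean on for this change. Removing the 3,5-dimethylphenyl group takes away the largest part of the substituent on the ring nitrogen, and the author expects the number for compound 4 to rise, a step estimated as a 10-fold higher number from compound 1 to compound 4 (1.00 log units; beyond the scatter). The value for compound 4 is therefore expected at about 400 nM, within a range from 100 nM to 2000 nM.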

Compound 4, half-maximal inhibitory concentration: 340 nM
Estimate against measurement, compound 4: 1.2-fold (0.07 log units) above, within the range that was stated.
By their numbers in this assay, from the lowest: compounds 1 and 3 (each within the scatter of the next); then compounds 4 and 2 (each within the scatter of the next).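

Within the data shown here, replacing 3,5-dimethylphenyl with hydrogen on a saturated chain carbon bound to an amide-type nitrogen in a ring gives the only one-place step in this set, an 8.5-fold higher number from compound 1 to compound 4 (0.93 log units; beyond the scatter), in this assay. It shows that, on the core of compound 1, the 3,5-dimethylphenyl group at this place is tied to a clear part of the low number, although compound 4, without it, still gives a measurable 340 nM in the same assay. Nothing available explains the size of this step.

The compounds shown leave open whether a plain phenyl without the two methyl groups, or a longer chain ending in an amine, would keep the number of compound 1 at this place. With hydrogen and 3,5-dimethylphenyl alone compared there, no trend across groups can be drawn.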